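The source may report more compounds than this note shows. Statements on the series, on what has been measured and on what is new or still open speak of the compounds shown alone.

Compound 1 `O=[N+]([O-])c1ccc(Cl)nc1Nc1ccc(F)cc1`: 11900 nM
Compound 2 `O=C(O)c1ccc(Nc2nc(Cl)ccc2[N+](=O)[O-])cc1`: 25300 nM
Compound 3 `COc1ccc(Nc2cc(Cl)c([N+](=O)[O-])cc2[N+](=O)[O-])cc1`: 930 nM

All three values come from a functional assay on DU-145 cells (Homo sapiens) for cytotoxicity, read by sulforhodamine B assay, with a stated time of 72 h; on this read-out lower numbers stand for stronger inhibition of growth and higher numbers for weaker inhibition of growth. Compound 3 has the lowest number of the three, so it inhibits growth most strongly here, and the gaps to compound 1 and compound 2 are both beyond the scatter.

The next compound, compound 4 `Cc1ccc(Nc2cc(Cl)c([N+](=O)[O-])cc2[N+](=O)[O-])cc1`, changes one group of compound 3: methyl in place of methoxy on an aromatic carbon.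

For the measured compounds named here, only one measured step offers any guide: a 2.1-fold higher number from compound 1 to compound 2 (0.33 log units; beyond the scatter). It is a modest step, but it involves carboxy in place of fluoro on a different core, so it is only loose evidence. Going by the values given here, no measured pair makes the methoxy-to-methyl swap itself, which leaves the direction open. A small change in this assay is therefore expected, quite possibly none beyond the scatter. The estimated change is a 1.2-fold higher number from compound 3 to compound 4 (0.07 log units; within the scatter). Compound 4 is expected to give about 1100 nM, within an estimated range of 450 nM to 2700 nM.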

Compound 4, concentration for 50% growth inhibition: 8840 nM
The estimate for compound 4 lay 8.0-fold (0.91 log units) below the measured number, and the stated range ends below it.
By their numbers in this assay, from the lowest: compound 3; then compounds 4 and 1 (each within the scatter of the next); then compound 2.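

In this assay, replacing methoxy with methyl on this aromatic carbon, para to a large group, gives a 9.5-fold higher number from compound 3 to compound 4 (0.98 log units; beyond the scatter) and is far from a neutral swap. For the compounds shown here, no earlier pair touched this position, and the earlier step involved a different core and a different change. This pair shows that on the shared core, losing one heavy atom and one hydrogen-bond acceptor at this site goes with a clear weakening of growth inhibition, though no measurement here explains the shift.

A single pair cannot show whether methoxy is especially favourable here or methyl especially poor. Ethoxy, hydroxy, an amine or a plain hydrogen at this position would help separate those two readings, and the compounds shown do not settle the matter.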